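A fluoro step on the hydroxy compound

A few compounds are considered here, and "the series" means these few. Any claim that something is new, unique, unknown or untested is made for them only; others in the source may bear on it.

Measured so far in a functional assay on KB cells (Homo sapiens) for inhibition, read by sulforhodamine B assay (a lower number here means a stronger inhibitor of growth, a higher number a weaker inhibitor of growth), are these compounds:
Compound 1 `c1ccc(-c2ccc(-c3ccc(-c4nc5ccccc5[nH]4)cc3)cc2)cc1` gives 39700 nM
Compound 2 `Fc1ccc(-c2ccc(-c3ccc(-c4nc5ccccc5[nH]4)cc3)cc2)cc1` gives 41300 nM
Compound 3 `Oc1cccc2[nH]c(-c3ccc(-c4ccc(-c5ccccc5)cc4)cc3)nc12` gives 4010 nM

The hydroxy step was a 9.9-fold lower number from compound 1 to compound 3 (1.00 log units; beyond the scatter) and it leaves compound 3 with the lowest number of the three. Compound 4 `Oc1cccc2[nH]c(-c3ccc(-c4ccc(-c5ccc(F)cc5)cc4)cc3)nc12` is not yet measured. It adds to compound 3 fluoro in place of hydrogen on an aromatic carbon and nothing else. Going by the values given here, the one measured fluoro step is a 1.0-fold higher number from compound 1 to compound 2 (0.02 log units; within the scatter) and it was made without the hydroxy group present. No change beyond the scatter is therefore expected, and the estimated step is a 1.0-fold higher number from compound 3 to compound 4 (0.01 log units; within the scatter) in this reading. In this assay compound 4 is expected at 4100 nM with an estimated range from 2000 nM to 8200 nM for repeated measurements.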

Compound 4, concentration for 50% growth inhibition: 6920 nM
Beside the measured number, compound 4's estimate is 1.7-fold (0.23 log units) below it; measured number inside the range.
By their numbers in this assay, from the lowest: compounds 3 and 4 (each within the scatter of the next); then compounds 1 and 2 (each within the scatter of the next).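

With the hydroxy group present, the phenyl to 4-fluorophenyl change still stays within the scatter in this assay (a 1.7-fold higher number from compound 3 to compound 4 (0.24 log units; within the scatter)), so the fluoro group leaves the number in place on both cores: the same change on two cores in this assay, a 1.0-fold higher number (0.02 log units; within the scatter) from compound 1 to compound 2 and a 1.7-fold higher number (0.24 log units; within the scatter) from compound 3 to compound 4, 1.7-fold (0.22 log units) apart, within the scatter of two such steps. The hydroxy step also holds with the fluoro group present (a 6.0-fold lower number from compound 2 to compound 4 (0.78 log units; beyond the scatter)), and its size agrees on the two cores: the same change on two cores in this assay, a 9.9-fold lower number (1.00 log units; beyond the scatter) from compound 1 to compound 3 and a 6.0-fold lower number (0.78 log units; beyond the scatter) from compound 2 to compound 4, 1.7-fold (0.22 log units) apart, within the scatter of two such steps. Across these four compounds, the hydroxy group separates the pairs and the fluoro group does not. Going by these compounds, whether a methoxy group or an amine in place of the fluoro group would move the number beyond the scatter remains open.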